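The source may report more compounds than this note shows. Statements on the series, on what has been measured and on what is new or still open speak of the compounds shown alone.

In a functional assay on A549 cells (Homo sapiens) for inhibition, read by MTT assay, with a stated time of 72 h (a higher number here means a weaker inhibitor, a lower number a stronger inhibitor), compound 1 (`C=CC(=O)Nc1cc(Nc2nc3c(c(-c4cn(C)c5ccc(F)cc45)n2)CSCC3)c(OC)cc1N(C)CCN(C)C`) gives 4550 nM, compound 2 (`C=C(Cl)C(=O)Nc1cc(Nc2nc3c(c(-c4cn(C)c5ccc(F)cc45)n2)CSCC3)c(OC)cc1N(C)CCN(C)C`) gives 864 nM and compound 3 (`C=CC(=O)Nc1cc(Nc2nc3c(c(-c4cn(C)c5ccccc45)n2)CSCC3)c(OC)cc1N(C)CCN(C)C`) gives 506 nM. Compound 3 and compound 2 lie within the scatter of each other, while compound 1 stands apart, with a 9.0-fold lower number from compound 1 to compound 3 (0.95 log units; beyond the scatter).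

Compound 4 (`C=C(Cl)C(=O)Nc1cc(Nc2nc3c(c(-c4cn(C)c5ccccc45)n2)CSCC3)c(OC)cc1N(C)CCN(C)C`) differs from compound 3 in one place: chloro in place of hydrogen on a double-bonded chain carbon bound to a carbonyl carbon. This is chloro in place of hydrogen on a double-bonded chain carbon bound to a carbonyl carbon, turning vinyl into 1-chloroethenyl.

The same change has been measured only once, with fluoro on the aromatic carbon, and there it gave a 5.3-fold lower number from compound 1 to compound 2 (0.72 log units; beyond the scatter). A single pair sets no pattern. Among the compounds with values here, that pair also starts from compound 1 at 4550 nM, and no pair yet shows the chloro change with hydrogen on that aromatic carbon. The fluoro-to-hydrogen step, a 9.0-fold lower number from compound 1 to compound 3 (0.95 log units; beyond the scatter), is a different change and indicates only that the starting point matters in this assay.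

The chloro step is therefore expected to carry over in the same direction, but only in part. The expected step is a 2.5-fold lower number from compound 3 to compound 4 (0.40 log units; beyond the scatter). For compound 4, the estimated value is 200 nM, with an expected range from 70 nM to 550 nM.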

Compound 4, half-maximal inhibitory concentration: 716 nM
The estimate for compound 4 lay 3.6-fold (0.55 log units) below the measured number; the measured number lies above the stated range.
By their numbers in this assay, from the lowest: compounds 3, 4 and 2 (each within the scatter of the next); then compound 1.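

In this assay, chloro in place of hydrogen on a double-bonded chain carbon bound to a carbonyl carbon brings no gain when the aromatic carbon bears hydrogen, with a 1.4-fold higher number from compound 3 to compound 4 (0.15 log units; within the scatter), so the effect of turning vinyl into 1-chloroethenyl depends on the core that carries it: the same change on two cores in this assay, a 5.3-fold lower number (0.72 log units; beyond the scatter) from compound 1 to compound 2 and a 1.4-fold higher number (0.15 log units; within the scatter) from compound 3 to compound 4, 7.5-fold (0.87 log units) apart, beyond the scatter of two such steps. The fluoro-to-hydrogen change likewise shrinks once 1-chloroethenyl is present, with a 1.2-fold lower number from compound 2 to compound 4 (0.08 log units; within the scatter), so its effect depends on the group on the double-bonded chain carbon: the same change on two cores in this assay, a 9.0-fold lower number (0.95 log units; beyond the scatter) from compound 1 to compound 3 and a 1.2-fold lower number (0.08 log units; within the scatter) from compound 2 to compound 4, 7.5-fold (0.87 log units) apart, beyond the scatter of two such steps. The two changes therefore do not add: in this set of four, each step from compound 1 lies beyond the scatter, and once either change is in place, the other gives a step within the scatter.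

On these data alone, it remains open whether compound 1 is a lone exception, or whether other groups on the aromatic carbon, such as chloro or methoxy, also give a higher number with vinyl and lose that difference with 1-chloroethenyl. Also open, as far as these compounds go, is whether bromo or methyl on the double-bonded chain carbon would behave as chloro does, and these cell numbers alone give no explanation for the dependence between the two places.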